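Aryl variation on the fused core against HeLa cells

The source may report more compounds than this note shows. Statements on the series, on what has been measured and on what is new or still open speak of the compounds shown alone.

compound 1 `COc1cc(-c2ccnc3c(-c4ccc(C)cc4)cnn23)cc(OC)c1OC` — > 10000 nM
compound 2 `COc1cc(-c2ccnc3cc(-c4ccc(C(C)(C)C)cc4)nn23)cc(OC)c1OC` — > 10000 nM
compound 3 `COc1cc(-c2ccnc3cc(-c4ccc(-c5cnn(C)c5)cc4)nn23)cc(OC)c1OC` — 1830 nM

In a functional assay on HeLa cells (Homo sapiens) for inhibition, read by CCK-8 assay, with a stated time of 48 h (on this read-out higher numbers stand for weaker inhibition and lower numbers for stronger inhibition), compound 1 gives > 10000 nM, which is a limit of the assay. Compound 2 also reaches only a limit, > 10000 nM, so it stands at the limit of > 10000 nM in this assay, at which 2 of the 3 values shown sit, and has no number of its own. Compound 3 gives 1830 nM in this assay. Within the data shown here, the single measured step that touches compound 2 is an at least 5.4-fold lower number from compound 2 to compound 3 (0.73 log units; beyond the scatter). Compound 4 `COc1cc(-c2ccnc3cc(-c4ccc(C)c(C)c4)nn23)cc(OC)c1OC` differs from compound 2 by 3,4-dimethylphenyl in place of 4-(tert-butyl)phenyl on an aromatic carbon. Unlike compound 3, compound 4 brings in no 1-methyl-1H-pyrazol-4-yl, only one six-membered aromatic ring of carbon only in place of another. The step expected is therefore a step that the limit leaves unreadable from compound 2 to compound 4, nothing beyond the scatter. For compound 4 the estimated value in this assay is 15000 nM, within 4000 nM to 50000 nM, most probably again only a limit.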

Compound 4, half-maximal inhibitory concentration: 241 nM
Estimate against measurement, compound 4: 62-fold (1.79 log units) above, and the stated range ends above it.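

At this position, on an aromatic carbon of the five-membered ring, replacing 4-(tert-butyl)phenyl with 3,4-dimethylphenyl gives in this assay an at least 41-fold lower number from compound 2 to compound 4 (1.61 log units; beyond the scatter). A large drop in the number therefore needs no 1-methyl-1H-pyrazol-4-yl, since a ring of carbon only suffices here. The true size of the step stays unknown because compound 2 has only a limit: the limit of > 10000 nM in this assay, at which 2 of the 4 values shown sit.

From the compounds shown here alone, whether one methyl group alone would carry the change stays open. So does the outcome with an amine or a carboxylic acid on this phenyl ring.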